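The source may hold more compounds than are shown below. What is called first, only, known or untested is meant among the compounds shown, and "the series" means these compounds.

Compound 2 `COc1ncnc2c1c(-c1ccoc1)cn2[C@@H]1O[C@H](CO)[C@@H](O)[C@H]1O` is the starting point. In a functional assay on A549 cells (Homo sapiens), read by MTT assay, with a stated time of 72 h (a lower number here means a stronger inhibitor, a higher number a weaker inhibitor), compound 2 gives 1160 nM, the lowest of the two plain numbers recorded. Compound 1 `COc1ncnc2c1c(-c1ccsc1)cn2[C@@H]1O[C@H](CO)[C@@H](O)[C@H]1O` in this assay gives 5170 nM, and the change is a 4.5-fold lower number from compound 1 to compound 2 (0.65 log units; beyond the scatter). Compound 3 `COc1nc(N)nc2c1c(-c1ccoc1)cn2[C@@H]1O[C@H](CO)[C@@H](O)[C@H]1O` in this assay gives only a limit, > 20000 nM, not a number. That step is an at least 17-fold higher number from compound 2 to compound 3 (1.23 log units; beyond the scatter). Compound 4 `CSc1ncnc2c1c(-c1ccoc1)cn2[C@@H]1O[C@H](CO)[C@@H](O)[C@H]1O` differs from compound 2 as follows: methylsulfanyl in place of methoxy on an aromatic carbon. Going by the values given here, no measured step changes the methoxy group itself; the only exchange of the same two elements is a 4.5-fold lower number from compound 1 to compound 2 (0.65 log units; beyond the scatter), which ran the other way and was modest. A modest rise in number is therefore expected, within roughly a 2.4-fold higher number from compound 2 to compound 4 (0.38 log units; beyond the scatter). Compound 4 is estimated in this assay at 2800 nM, between 900 nM and 9000 nM.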

Compound 4, half-maximal inhibitory concentration: 280 nM
For compound 4 the middle estimate is 10-fold (1.00 log units) above the measured one; measured number below the stated range.
By their numbers in this assay, from the lowest: compound 4; then compound 2; then compound 1. At a limit, above all of these: compound 3.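

Methylsulfanyl in place of methoxy, next to the ring nitrogen, gives a 4.1-fold lower number from compound 2 to compound 4 (0.62 log units; beyond the scatter) in this assay, the first measured sign that this position responds to change. Sulfur for oxygen lowers the number here, whereas at the other place the reverse exchange did so, a 4.5-fold lower number from compound 1 to compound 2 (0.65 log units; beyond the scatter), so swapping these two elements has no single direction across the two places. No measurement shown accounts for this contrast.

Going by these compounds, whether a longer chain such as ethylsulfanyl, or an amine, in this place would lower the number further stays open. So does whether methylsulfanyl would give a similar step on the core of compound 1.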